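Removal of the amino group on the shared core

The source may hold more compounds than are shown below. What is called first, only, known or untested is meant among the compounds shown, and "the series" means these compounds.

Among the compounds with values here, compound 2 `Nc1c(C2=NC3(CN2)CN2CCC3CC2)oc2ccccc12` gives 9% in an in vitro assay on SH-EP1 cells for displacement of a labelled ligand from Neuronal acetylcholine receptor; alpha4/beta2 (Homo sapiens), tested at 5 uM (on this read-out higher numbers stand for more inhibition at the one concentration tested (going by the name of the read-out) and lower numbers for less inhibition), and stands lowest of the two numbers so far. Its nearest neighbour, compound 1 `Oc1c(C2=NC3(CN2)CN2CCC3CC2)oc2ccccc12`, gives 32%. Within the data shown here, the one step between measured compounds, a number 23 percentage points lower from compound 1 to compound 2 (beyond the scatter), lies beyond the scatter. Compound 3 `c1ccc2oc(C3=NC4(CN3)CN3CCC4CC3)cc2c1` differs from compound 2 in one place: hydrogen in place of amino on an aromatic carbon. Among the measured compounds shown here, the step from compound 1 to compound 2 bears on this change in that it concerns the same place on the shared core, but no measured step removes the group there entirely, so it sets only the scale of what one change at this place has done, a modest step. The direction for compound 3 cannot be read from compound 1 and compound 2 together; hydroxy gave the higher number, amino the lower, and the bare position lies outside either. The step of a number 6 percentage points higher from compound 2 to compound 3 (within the scatter) is expected to be small, within or close to the scatter. Compound 3 is estimated at 15%, with a range from 0% to 35%.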

Compound 3, a percentage reported as inhibition, at one concentration (the size of the read-out at that concentration, not a potency): 4%
Compound 3: middle estimate off by 11 percentage points, on the high side; the measured number falls inside the stated range.
By their numbers in this assay, from the lowest: compounds 3 and 2 (each within the scatter of the next); then compound 1.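

In this assay the step of a number 5 percentage points lower from compound 2 to compound 3 (within the scatter) leaves amino and hydrogen unresolved on this aromatic carbon of the five-membered aromatic ring, so removing amino has no effect that can be read at this single concentration. Within the data shown here, the step of a number 28 percentage points lower from compound 1 to compound 3 (beyond the scatter) adds the direct comparison of hydroxy with hydrogen at the same place, which the earlier compounds lacked, and makes hydroxy the only one of the three groups that stands apart, with compound 1 beyond the scatter of both other compounds. No measurement at hand bears on why hydroxy differs from amino and hydrogen here.

The compounds shown leave open whether the higher number belongs to hydroxy alone or also extends to other groups on this carbon, such as methoxy, a methyl group or chlorine. They also leave open whether any group at this place can raise the number well beyond that of compound 1 32%, and how these single-concentration numbers would translate into potency.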